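Replacing 4-methoxyphenyl with 4-methylphenyl: compound 4 awaits

The compounds below may be only part of what the source reports. "The series", "measured", "known", "first", "only" and "open" are said of these compounds alone.

Among the compounds with values here, in a functional assay on A549 cells (Homo sapiens) for cytotoxicity, read by MTT assay, with a stated time of 72 h (on this read-out lower numbers stand for stronger inhibition and higher numbers for weaker inhibition), compound 3 `CNC(=O)c1cc(Oc2ccc(NC(=O)c3nccc(-c4ccc(OC)cc4)n3)cc2)ccn1` gives 11100 nM, the lower of the two actual numbers so far, and compound 1 `CNC(=O)c1cc(Oc2ccc(NC(=O)c3nccc(-c4ccccc4)n3)cc2)ccn1` gives 26200 nM. Compound 2 `CNC(=O)c1cc(Oc2ccc(NC(=O)c3nccc(-c4cccc(Cl)c4)n3)cc2)ccn1` reads > 100000 nM, which is a limit of the assay and not a number.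

Compound 4 `CNC(=O)c1cc(Oc2ccc(NC(=O)c3nccc(-c4ccc(C)cc4)n3)cc2)ccn1` carries methyl in place of methoxy on an aromatic carbon, para to a large group (methyl in place of methoxy on an aromatic carbon). Within the data shown here, no measured step covers methyl itself. The closest guide is methoxy in place of hydrogen, which gave a 2.4-fold lower number from compound 1 to compound 3 (0.37 log units; beyond the scatter). Chloro in place of hydrogen gave an at least 3.8-fold higher number from compound 1 to compound 2 (0.58 log units; beyond the scatter), and the change of aryl group gave an at least 9.0-fold lower number from compound 2 to compound 3 (0.95 log units; beyond the scatter), but both of these steps rest on a limit and involve chloro, so they carry less weight. Losing the methoxy is therefore expected to give back part of the modest change seen with compound 3. The expected change is a 1.5-fold higher number from compound 3 to compound 4 (0.19 log units; within the scatter), a small rise in the number. For compound 4 the estimated value is 17000 nM, with an expected range of 6000 nM to 45000 nM.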

Compound 4, half-maximal inhibitory concentration: 28400 nM
For compound 4 the middle estimate is 1.7-fold (0.22 log units) below the measured one, within the range that was stated.
By their numbers in this assay, from the lowest: compound 3; then compounds 1 and 4 (each within the scatter of the next). At a limit, above all of these: compound 2.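

In this assay the methoxy group, para to a large group, turns out to be the one that stands apart: methyl in its place gives a 2.6-fold higher number from compound 3 to compound 4 (0.41 log units; beyond the scatter), whereas methyl in place of hydrogen gives a 1.1-fold higher number from compound 1 to compound 4 (0.04 log units; within the scatter). At this position, then, methyl cannot be told apart from hydrogen, and the lower number of compound 3 goes with methoxy and not with just any group there. Against the 3-chlorophenyl compound, the 4-methylphenyl compound shows an at least 3.5-fold lower number from compound 2 to compound 4 (0.54 log units; beyond the scatter), but this is a bound only, as compound 2 rests on a limit: the limit of > 100000 nM in this assay, at which 1 of the 4 values shown sits.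

Going by these compounds, it remains open whether a hydroxyl, an ethoxy or a dimethylamino group at this place would go with methoxy or with methyl and hydrogen. Also open, on these data alone, is how far compound 2 really lies from the others.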